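Swapping the oxadiazole for an oxazole in Caco-2 permeability

The compounds below may be only part of what the source reports. "The series", "measured", "known", "first", "only" and "open" are said of these compounds alone.

Compound 1 `Cn1cc(-c2nc3c(-c4ccc(CNC(=O)c5ccc(C(C)(C)C)cc5)c(F)c4)ccnc3[nH]2)cn1`: 0.4 10^-6 cm/s in an ADME assay on Caco-2 cells (Homo sapiens) for permeability, in the apical to basolateral direction; a higher number here means that the compound crosses the layer faster, a lower number that the compound crosses the layer more slowly
Compound 2 `Cn1cc(-c2nc3c(-c4ccc(CNC(=O)c5nc(C(C)(C)C)no5)c(F)c4)ccnc3[nH]2)cn1`: 11 10^-6 cm/s
Compound 3 `Cn1cc(-c2nc3c(-c4ccc(CNC(=O)c5noc(C(C)(C)C)n5)c(F)c4)ccnc3[nH]2)cn1`: 2.5 10^-6 cm/s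

Compound 3 sits second highest of the three numbers: the measured steps show a 4.4-fold lower number from compound 2 to compound 3 (0.64 log units; beyond the scatter) and a 6.3-fold higher number from compound 1 to compound 3 (0.80 log units; beyond the scatter), both modest but beyond the scatter.

Compound 4 `Cn1cc(-c2nc3c(-c4ccc(CNC(=O)c5cc(C(C)(C)C)no5)c(F)c4)ccnc3[nH]2)cn1` differs from compound 3 in one place: 3-(tert-butyl)-1,2-oxazol-5-yl in place of 5-(tert-butyl)-1,2,4-oxadiazol-3-yl on a carbonyl carbon. Going by the values given here, no measured step makes exactly this change. The closest guide is the exchange of one five-membered ring for another, which gave a 4.4-fold lower number from compound 2 to compound 3 (0.64 log units; beyond the scatter), and the larger move away from the phenyl ring, a 6.3-fold higher number from compound 1 to compound 3 (0.80 log units; beyond the scatter). Because a 4.4-fold lower number from compound 2 to compound 3 (0.64 log units; beyond the scatter) was only modest, a small change is expected here too. In this assay compound 4 is therefore expected to shift by a 2.0-fold higher number from compound 3 to compound 4 (0.30 log units; within the scatter), landing between the two nearest measured numbers. Compound 4 is estimated at 5 10^-6 cm/s, with a likely range from 1.5 10^-6 cm/s to 15 10^-6 cm/s.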

Compound 4, apparent permeability: 3 10^-6 cm/s
The estimate for compound 4 lay 1.7-fold (0.22 log units) above the measured number; measured number inside the range.
By their numbers in this assay, from the lowest: compound 1; then compounds 3 and 4 (each within the scatter of the next); then compound 2.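

In this assay, placing 3-(tert-butyl)-1,2-oxazol-5-yl instead of 5-(tert-butyl)-1,2,4-oxadiazol-3-yl on this carbonyl carbon gives a 1.2-fold higher number from compound 3 to compound 4 (0.08 log units; within the scatter), so removing one ring nitrogen here leaves the number within the scatter. The other two new steps lie beyond the scatter: a 3.7-fold lower number from compound 2 to compound 4 (0.56 log units; beyond the scatter), and a 7.5-fold higher number from compound 1 to compound 4 (0.88 log units; beyond the scatter), so the new ring stays clear of the phenyl compound yet does not match the highest number. Nothing shown explains these differences.

Going by these compounds, what remains open is how this position would respond if a cyclopropyl group or a trifluoromethyl group replaced the tert-butyl group on the ring.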